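The compounds below may be only part of what the source reports. "The series", "measured", "known", "first", "only" and "open" are said of these compounds alone.

Working notes on the series. Going by the values given here, in an ADME assay on CHO cells (Cricetulus griseus) for cytotoxicity, read by LDH release (a lower number here means a stronger inhibitor, a higher number a weaker inhibitor), compound 2 `CC(Oc1ccc(Cl)cc1Cl)C(=O)NCc1ccc(Cl)cc1` gives 39000 nM and compound 3 `COc1ccc(CNC(=O)C(C)Oc2ccc(Cl)cc2Cl)cc1` gives 71000 nM, the only two actual numbers so far. The gap is a 1.8-fold higher number from compound 2 to compound 3 (0.26 log units; within the scatter), so compound 2 and compound 3 stand level. Compound 1 `CCCCC(NC(=O)C(C)Oc1ccc(Cl)cc1Cl)c1ccc(F)cc1` reads > 100000 nM, which is a limit of the assay and not a number.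

The next step leads to compound 4 `CC(Oc1ccc(Cl)cc1Cl)C(=O)NCc1ccc(F)cn1`, reached from compound 2 by 5-fluoropyridin-2-yl in place of 4-chlorophenyl on a saturated chain carbon bound to an amide-type nitrogen. In words, this puts 5-fluoropyridin-2-yl in place of 4-chlorophenyl on a saturated chain carbon bound to an amide-type nitrogen.

Among the compounds with values here, only one measured step bears on this: a 1.8-fold higher number from compound 2 to compound 3 (0.26 log units; within the scatter), where methoxy replaces chloro on an aromatic carbon. Within the data shown here, no measured step yet changes the ring itself, so the support is thin. A small move towards a higher number in this assay is expected, not much beyond the scatter. The expected change is a 1.8-fold higher number from compound 2 to compound 4 (0.25 log units; within the scatter). For compound 4 the estimate is 70000 nM, with an expected range of 35000 nM to 130000 nM.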

Compound 4, half-maximal inhibitory concentration: > 100000 nM
Compound 4 was reported as a limit; the forecaster's own chance of this, stated with the estimate: 35%; at least 1.4-fold (0.15 log units) between middle value and limit.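

In this assay, putting 5-fluoropyridin-2-yl in place of 4-chlorophenyl on a saturated chain carbon bound to an amide-type nitrogen gives an at least 2.5-fold higher number from compound 2 to compound 4 (0.40 log units; beyond the scatter). Unlike the methoxy-for-chloro step, which stayed within the scatter, this step shows that replacing the ring itself at this position can move the number beyond the scatter. The full size of the step cannot be read, because compound 4 gives a limit of the assay and not a number: the limit of > 100000 nM in this assay, at which 2 of the 4 values shown sit.

The ring nitrogen and the fluorine enter together, so the compounds shown do not separate their contributions to the step. As far as these compounds go, how a plain phenyl group, or a pyridine ring carrying an amine in place of the fluorine, would read at this position also remains open.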